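Working notes: from compound 3 to compound 4

This account rests on a few compounds, and the source may have more. Where it says the series, first, only, none or still open, it means among the compounds named here.

Measured compounds:
compound 1 `Cc1ccc(S(=O)(=O)NCc2cn(C[C@H](O)[C@H]3OC(=O)C(OCc4ccccc4)=C3OCc3ccccc3)nn2)cc1`, 6400 nM
compound 2 `O=C1O[C@H]([C@@H](O)Cn2cc(CNS(=O)(=O)c3ccc(F)cc3)nn2)C(OCc2ccccc2)=C1OCc1ccccc1`, 26800 nM
compound 3 `O=C1O[C@H]([C@@H](O)Cn2cc(CCO)nn2)C(OCc2ccccc2)=C1OCc1ccccc1`, 63400 nM

The three compounds share one core and differ only in the group on the five-membered aromatic ring with 3 nitrogen. In a functional assay on MCF7 cells (Homo sapiens) for antiproliferative activity, read by MTT assay, with a stated time of 72 h (a higher number here means a weaker inhibitor, a lower number a stronger inhibitor), compound 3 gives the highest number of the three; compound 2 stands nearest with a 2.4-fold higher number from compound 2 to compound 3 (0.37 log units; beyond the scatter), and compound 1 furthest with a 9.9-fold higher number from compound 1 to compound 3 (1.00 log units; beyond the scatter). Both steps into compound 3 replaced a ((4-methylphenyl)sulfonyl)amino or ((4-fluorophenyl)sulfonyl)amino group by hydroxymethyl, and both raised the number beyond the scatter.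

Compound 4 `COc1ccccc1-c1cn(C[C@H](O)[C@H]2OC(=O)C(OCc3ccccc3)=C2OCc2ccccc2)nn1` has not been measured in this assay. Its change from compound 3: 2-methoxyphenyl in place of 2-hydroxyethyl on an aromatic carbon. Among the measured compounds shown here, no measured pair carries an aromatic ring bound directly to that ring carbon, so the bearing steps are indirect: both show that moving from a group containing an aromatic ring to a short hydroxy-bearing chain weakened inhibition. Reversing that direction with a 2-methoxyphenyl is therefore expected to lower the number, by something nearer the size of a 2.4-fold higher number from compound 2 to compound 3 (0.37 log units; beyond the scatter) than of a 9.9-fold higher number from compound 1 to compound 3 (1.00 log units; beyond the scatter), with wide uncertainty. Compound 4 is estimated at 25000 nM (range 8000 nM to 70000 nM). The expected step is a 2.5-fold lower number from compound 3 to compound 4 (0.40 log units; beyond the scatter).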

Compound 4, half-maximal inhibitory concentration: > 100000 nM
Compound 4 was reported as a limit (the forecaster's own chance of this, stated with the estimate: 10%); middle value at least 4.0-fold (0.60 log units) away from the limit.
By their numbers in this assay, from the lowest: compound 1; then compound 2; then compound 3. At a limit, above all of these: compound 4.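

Compound 4 in this assay is reported only as a limit, not as a number: the limit of > 100000 nM in this assay, at which 1 of the 4 values shown sits. With 2-methoxyphenyl bound directly to the aromatic carbon, there is an at least 15-fold higher number from compound 1 to compound 4 (1.19 log units; beyond the scatter) and also an at least 3.7-fold higher number from compound 2 to compound 4 (0.57 log units; beyond the scatter) on replacing the (((4-methylphenyl)sulfonyl)amino)methyl and (((4-fluorophenyl)sulfonyl)amino)methyl groups, so an aromatic ring in the group at this position is not enough on its own to give the lower numbers of compound 1 and compound 2. Against the 2-hydroxyethyl group there is an at least 1.5-fold higher number from compound 3 to compound 4 (0.19 log units; that floor lies within the scatter) and that floor lies within the scatter, yet the result shows no gain from the 2-methoxyphenyl group, which the earlier steps into compound 3 could not show.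

Going by these compounds, how far the true value of compound 4 lies past its limit remains unknown, so the full size of all three steps stays open. Also open, on these data alone, is which part of the sulfonylamino-bearing groups goes with the lower numbers, a question that an aminomethyl group, a benzyl group or an unsubstituted phenyl group on the same carbon would bear on.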